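The source may report more compounds than this note shows. Statements on the series, on what has been measured and on what is new or still open speak of the compounds shown alone.

Compound 3 `Cc1ccc(Nc2ncc([C@H](NC(=O)c3nccs3)C(C)C)cc2Cl)cn1` stands lowest of the three compounds measured in a functional assay on HEK293 cells for negative allosteric modulation of metabotropic glutamate receptor 5 (Homo sapiens), read by HTRF and inositol phosphate accumulation (on this read-out lower numbers stand for stronger inhibition and higher numbers for weaker inhibition), where compound 3 gives 7.5 nM. Compound 1 `CCCC(NC(=O)c1nccs1)c1cnc(Nc2ccc(C)nc2)c(Cl)c1` gives 28.7 nM, and compound 2 `Cc1ccc(Nc2ncc([C@@H](NC(=O)c3nccs3)C(C)C)cc2Cl)cn1` gives 1060 nM. Within the data shown here, the only measured step that changes a single feature is a 140-fold lower number from compound 2 to compound 3 (2.15 log units; beyond the scatter), and it rests on the fact that (the fact that compounds 2 and 3 differ only in the configuration as drawn). Compound 4 `Cc1ccc(Nc2ncc([C@H](NC(=O)c3nccs3)C3CCCC3)cc2Cl)cn1` differs from compound 3 by cyclopentyl in place of isopropyl on a saturated chain carbon bound to an amide-type nitrogen and an aromatic carbon. Among the measured compounds shown here, no measured step alters this group on its own; compound 1 carries a different chain there and is drawn without a configuration, so only its value can be set beside that of compound 3. The step of a 1.3-fold higher number from compound 3 to compound 4 (0.12 log units; within the scatter) is therefore expected to be modest. Compound 4 is expected to give 10 nM, within 3 nM to 35 nM.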

Compound 4, half-maximal inhibitory concentration: 16.6 nM
Compound 4: middle estimate off by 1.7-fold (0.22 log units), on the low side, and the stated range covers the measured number.
By their numbers in this assay, from the lowest: compound 3; then compounds 4 and 1 (each within the scatter of the next); then compound 2.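

In this assay, cyclopentyl in place of isopropyl on a saturated chain carbon bound to an amide-type nitrogen and an aromatic carbon gives a 2.2-fold higher number from compound 3 to compound 4 (0.35 log units; beyond the scatter). Among these compounds, this is the first measured step at this position that alters the group itself rather than the configuration as drawn, and it is far smaller than a 140-fold lower number from compound 2 to compound 3 (2.15 log units; beyond the scatter). Nothing given here accounts for the size of this step. The compounds shown leave open how cyclobutyl, cyclohexyl or phenyl would fare at this position. They also leave open whether cyclopentyl drawn with the opposite configuration would show a loss like that of compound 2.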